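Swapping a benzyl ether for a propargyl ether

The source may hold more compounds than are shown below. What is called first, only, known or untested is meant among the compounds shown, and "the series" means these compounds.

Measured compounds:
- compound 1 `O=C1c2ccccc2N(COCc2ccccc2)S(=O)(=O)N1Cc1ccccc1`: 25000 nM
- compound 2 `O=C1c2ccccc2N(Cc2ccccc2Cl)S(=O)(=O)N1COCc1ccccc1`: 22200 nM
- compound 3 `O=C1c2ccccc2N(Cc2ccccc2)S(=O)(=O)N1Cc1ccccc1Cl`: > 250000 nM

In a functional assay on CCRF-CEM cells (Homo sapiens) for inhibition (on this read-out higher numbers stand for lower toxicity in this test and lower numbers for higher toxicity in this test), compound 1 gives 25000 nM. Compound 2 sits at practically the same number, and the gap between them is within the usual scatter. For compound 3 the result is only a limit of the assay, (the limit of > 250000 nM in this assay, at which 1 of the 3 values shown sits).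

Compound 4 `C#CCOCN1c2ccccc2C(=O)N(Cc2ccccc2)S1(=O)=O` keeps the shared core and the benzyl on the other nitrogen, and differs from compound 1 in one place: ethynyl in place of phenyl on a saturated chain carbon bound to an oxygen on a saturated carbon. Among the compounds with values here, no measured pair shows what such a change does here, so the expectation rests on compound 1 alone. The step is expected to be small, a 1.2-fold higher number from compound 1 to compound 4 (0.08 log units; within the scatter), not clearly beyond the scatter in either direction. Compound 4 is therefore estimated at 30000 nM, with a likely range from 10000 nM to 100000 nM.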

Compound 4, half-maximal cytotoxic concentration: 23000 nM
Estimate against measurement, compound 4: 1.3-fold (0.12 log units) above; measured number inside the range.
By their numbers in this assay, from the lowest: compounds 2, 4 and 1 (each within the scatter of the next). At a limit, above all of these: compound 3.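

Within the data shown here, replacing phenyl with ethynyl on this saturated chain carbon, the change from benzyloxy to propargyloxy, gives the first single-change comparison: this assay shows a 1.1-fold lower number from compound 1 to compound 4 (0.04 log units; within the scatter). At this position, then, the aromatic ring at the end of the ether chain can give way to a triple bond without a clear shift in the number. No measurement shown explains this outcome.

On these data alone, whether an amine, a carboxylic acid or a longer chain at this place would also leave the number within the scatter remains open.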